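The compounds below may be only part of what the source reports. "The series", "measured", "known", "first", "only" and "open" are said of these compounds alone.

Measured so far in a functional assay on HOS cells (Homo sapiens) for antiproliferative activity, with a stated time of 72 h; on this read-out lower numbers stand for stronger inhibition and higher numbers for weaker inhibition (all three values are limits):
- Compound 1 `OC[C@H]1O[C@@H](n2cnc3c(NCc4ccccc4Cl)ncnc32)[C@H](O)[C@@H]1O` gives > 166000 nM
- Compound 2 `COc1ccccc1CNc1ncnc2c1ncn2[C@@H]1O[C@H](CO)[C@@H](O)[C@H]1O` gives > 166000 nM
- Compound 3 `OC[C@H]1O[C@@H](n2cnc3c(NCc4cc(O)cc(O)c4)ncnc32)[C@H](O)[C@@H]1O` gives > 166000 nM

Compound 3 has no number, only a limit, and it shares that position with the other two compounds. Going by the values given here, the series so far stands at one place: the limit of > 166000 nM in this assay, at which 3 of the 3 values shown sit.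

The next compound is compound 4 `OC[C@H]1O[C@@H](n2cnc3c(NCc4ccccc4OC(F)F)ncnc32)[C@H](O)[C@@H]1O`, and the change leading to it is 2-(difluoromethoxy)phenyl in place of 3,5-dihydroxyphenyl on a saturated chain carbon bound to a nitrogen on an aromatic ring. The 3,5-dihydroxyphenyl group leaves, and 2-(difluoromethoxy)phenyl enters on the same saturated chain carbon bound to a nitrogen on an aromatic ring.

The closest measured evidence is a step that the two limits leave unreadable from compound 2 to compound 3, which also concerns the 3,5-dihydroxyphenyl group. Next comes a step that the two limits leave unreadable from compound 1 to compound 3, which concerns that group as well. The remaining evidence is a step that the two limits leave unreadable from compound 1 to compound 2, where methoxy stands in place of chloro on an aromatic carbon. Each of these steps has a limit at both ends, so none gives a size or a direction to carry over.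

No step beyond the scatter is therefore expected in this assay, and a reported limit is the likeliest outcome. The expected change is a number no higher from compound 3 to compound 4 (the limit leaves the size open). For compound 4 the estimate is 166000 nM, with an expected range from 60000 nM to 400000 nM.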

Compound 4, half-maximal inhibitory concentration: > 166000 nM
Compound 4 was reported as a limit; the forecaster's own chance of this, stated with the estimate: 85%; the middle value lies on the limit itself.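

In this assay compound 4 gives > 166000 nM, which is a limit. The steps from compound 1, compound 2 and compound 3 to compound 4 cannot be read, and the series stays at one place: the limit of > 166000 nM in this assay, at which 4 of the 4 values shown sit.

The compounds shown leave open how far apart these four lie and whether any change on the saturated chain carbon gives a measurable number in this assay.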